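A few compounds are considered here, and "the series" means these few. Any claim that something is new, unique, unknown or untested is made for them only; others in the source may bear on it.

Measured compounds and their values in an assay on isolated protein for inhibition of histone deacetylase 4 (Homo sapiens), with a stated time of 1 h; on this read-out higher numbers stand for weaker inhibition and lower numbers for stronger inhibition:

compound 1, `O=C(COc1ccc2cc(/C=C3/SC(=O)NC3=O)ccc2c1)Nc1ccc(F)cc1`: 1600 nM
compound 2, `Cc1ccc(NC(=O)COc2ccc3cc(/C=C4/SC(=O)NC4=O)ccc3c2)cc1Cl`: 1100 nM

Both compounds share one core, and differ only in the aryl group on the amide-type nitrogen. Going by the values given here, compound 2 carries the smaller of the two numbers so far, but the step of a 1.5-fold lower number from compound 1 to compound 2 (0.16 log units; within the scatter) is within the scatter, so nothing separates it from compound 1 with confidence. Compound 3, `O=C(COc1ccc2cc(/C=C3/SC(=O)NC3=O)ccc2c1)Nc1cc(Cl)cc(C(F)(F)F)c1`, keeps that core and again changes only the aryl group: 3-chloro-5-(trifluoromethyl)phenyl in place of 3-chloro-4-methylphenyl on an amide-type nitrogen. Among the compounds with values here, the only measured step that bears on this, from compound 1 to compound 2, also swapped one aryl group on that nitrogen for another and stayed within the scatter. On that basis the change to compound 3 is expected to produce no step beyond the scatter in this assay, in either direction. Compound 3 is therefore expected to give about 1200 nM, with a range from 500 nM to 3000 nM. The expected step of a 1.1-fold higher number from compound 2 to compound 3 (0.04 log units; within the scatter) lies within the scatter.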

Compound 3, half-maximal inhibitory concentration: 4000 nM
Compound 3: middle estimate off by 3.3-fold (0.52 log units), on the low side, outside the stated range (above it).
By their numbers in this assay, from the lowest: compounds 2 and 1 (each within the scatter of the next); then compound 3.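

In this assay, the aryl group on the amide-type nitrogen can move the number beyond the scatter, which the step between compound 1 and compound 2 did not show. Putting 3-chloro-5-(trifluoromethyl)phenyl in place of 3-chloro-4-methylphenyl gives a 3.6-fold higher number from compound 2 to compound 3 (0.56 log units; beyond the scatter) and putting it in place of 4-fluorophenyl gives a 2.5-fold higher number from compound 1 to compound 3 (0.40 log units; beyond the scatter) so both steps point towards weaker inhibition, though both are modest in size. Nothing available here offers a reason for this shift.

Still open, as far as these compounds go, is whether a trifluoromethyl group without the chlorine would give a step of similar size. From the compounds shown here alone, it is also open how an amine or a carboxylic acid on this aryl group, or a plain alkyl chain in place of the aryl group, would read in this assay on this same nitrogen.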